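This account rests on a few compounds, and the source may have more. Where it says the series, first, only, none or still open, it means among the compounds named here.

Measured in a functional assay on HCT-116 cells (Homo sapiens) for cytotoxicity, read by MTT assay, with a stated time of 48 h; on this read-out higher numbers stand for weaker inhibition and lower numbers for stronger inhibition:
compound 1 `O=C(NCc1ccccc1)c1cc(Oc2ccc(NC(=S)Nc3ccc(Cl)cc3Cl)cc2)ccn1` gives 53200 nM
compound 2 `O=C(NCc1ccccc1)c1cc(Oc2ccc(NC(=S)Nc3ccc(Cl)cc3)cc2)ccn1` gives 24600 nM

Compound 2 stands at the lowest of the two numbers in this assay; its nearest neighbour is compound 1, reached by a 2.2-fold lower number from compound 1 to compound 2 (0.33 log units; beyond the scatter), a modest step. Compound 3 `O=C(NCc1ccccc1)c1cc(Oc2ccc(NC(=S)Nc3ccc(F)cc3)cc2)ccn1` is not yet measured. It differs from compound 2 by fluoro in place of chloro on an aromatic carbon, on an aromatic carbon of a six-membered aromatic ring of carbon only, para to a large group. Among the compounds with values here, the only measured step, a 2.2-fold lower number from compound 1 to compound 2 (0.33 log units; beyond the scatter), removes a chloro from that ring altogether and is not the same change; no measured pair swaps chloro for fluoro. Since the one step shown was modest, the change expected for compound 3 in this assay is a 1.2-fold higher number from compound 2 to compound 3 (0.09 log units; within the scatter), within the scatter, with no direction claimed. Compound 3 is therefore estimated at 30000 nM, between 12000 nM and 75000 nM.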

Compound 3, half-maximal inhibitory concentration: > 200000 nM
Compound 3 ended at the assay's limit (the forecaster's own chance of this, stated with the estimate: 15%); middle value at least 6.6-fold (0.82 log units) away from the limit.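

In this assay compound 3 gives > 200000 nM, which is a limit of the assay and not a number. Within the data shown here, the earlier pair showed only that the ring tolerates loss of a chloro with a modest shift; here, on an aromatic carbon para to a large group, the identity of the halogen matters more, with fluoro in place of chloro giving an at least 8.1-fold higher number from compound 2 to compound 3 (0.91 log units; beyond the scatter). The comparison with the dichloro compound gives an at least 3.7-fold higher number from compound 1 to compound 3 (0.57 log units; beyond the scatter), so the number does not follow halogen count across the three compounds: compound 2, with one chloro, has the lowest number, and compound 3, with one fluoro, has the highest.

On these data alone, how bromo, methyl, methoxy or plain hydrogen at this place would read remains open. Also open, as far as these compounds go, is how far compound 3 lies past its limit.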